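Swapping chloro for fluoro on the side ring

This account rests on a few compounds, and the source may have more. Where it says the series, first, only, none or still open, it means among the compounds named here.

Measured compounds:
compound 1 `CC1=C(/C=C/C(=O)/C=C/c2ccc(Cl)cc2)C(C)(C)CCC1` – 52300 nM
compound 2 `CC1=C(/C=C/C(=O)/C=C/c2ccc([N+](=O)[O-])cc2)C(C)(C)CCC1` – 3200 nM
compound 3 `CC1=C(/C=C/C(=O)/C=C/c2ccccc2Cl)C(C)(C)CCC1` – 13700 nM

These three share one core and differ only in the substituted phenyl ring at the end of the chain. In a functional assay on IMR-32 cells (Homo sapiens) for cytotoxicity, read by sulforhodamine B assay, with a stated time of 48 h (a lower number here means a stronger inhibitor, a higher number a weaker inhibitor), compound 2 gives the lowest number, compound 3 stands second highest, and compound 1 gives the highest number. The step of a 16-fold lower number from compound 1 to compound 2 (1.21 log units; beyond the scatter) is large; the step of a 3.8-fold lower number from compound 1 to compound 3 (0.58 log units; beyond the scatter) is modest.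

Compound 4 `CC1=C(/C=C/C(=O)/C=C/c2ccccc2F)C(C)(C)CCC1` has not yet been measured. Compared with compound 3 the change is fluoro in place of chloro on an aromatic carbon. Going by the values given here, no measured step exchanges one halogen for another, so none bears on it directly. Among the compounds with values here, the only change of a group at one aromatic carbon, from chloro to nitro, was large, but fluoro and chloro are far more alike than chloro and nitro. Compound 4 is therefore expected to stay close to compound 3, with a step of a 1.3-fold higher number from compound 3 to compound 4 (0.12 log units; within the scatter) that may lie within the scatter. Compound 4 is estimated at 18000 nM, within 7000 nM to 45000 nM.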

Compound 4, half-maximal inhibitory concentration: 15600 nM
The estimate for compound 4 lay 1.2-fold (0.06 log units) above the measured number; measured number inside the range.
By their numbers in this assay, from the lowest: compound 2; then compounds 3 and 4 (each within the scatter of the next); then compound 1.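

In this assay, the step of a 1.1-fold higher number from compound 3 to compound 4 (0.06 log units; within the scatter) shows that fluoro and chloro cannot be told apart on this aromatic carbon, ortho to a large group. The earlier compounds shown here showed changes only between unlike groups or between places on the ring, whereas this pair exchanges one halogen for another at a fixed place. The step of a 3.4-fold lower number from compound 1 to compound 4 (0.53 log units; beyond the scatter) is also modest, so the 2-fluorophenyl and 2-chlorophenyl compounds both give lower numbers than the 4-chlorophenyl compound in this small set.

No measurement shown here explains why the two halogens give such similar numbers. From the compounds shown here alone, it remains open whether an amine or a methoxy group on the same aromatic carbon would keep the number near those of the two halogens or move it.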